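A few compounds are considered here, and "the series" means these few. Any claim that something is new, unique, unknown or untested is made for them only; others in the source may bear on it.

In a functional assay on T98G cells (Homo sapiens) for inhibition, read by colorimetric assay and MTT assay, with a stated time of 72 h (a lower number here means a stronger inhibitor, a higher number a weaker inhibitor), compound 1 `Cn1c2cnc1OCCCCCCCCOc1ccc(F)cc1-2` gives 77000 nM and compound 2 `Cn1c2cnc1OCCCCCCCCOc1cc(F)ccc1-2` gives 69000 nM as its value, two numbers within the usual scatter of each other. Compound 3 `C=CCCCCOc1ccccc1-c1cnc(OCCC=C)n1C` gives 29000 nM on the same scale, the lowest number of the three and beyond the scatter from both of the others, which makes it the strongest inhibitor of this small set.

Compound 4 `C=CCCCCOc1ccc(F)cc1-c1cnc(OCCC=C)n1C` has not yet been measured. It differs from compound 3 in one place only: fluoro in place of hydrogen on an aromatic carbon is the whole change, fluoro in place of hydrogen on an aromatic carbon, para to a (hex-5-en-1-yl)oxy group.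

For the measured compounds named here, no measured pair of compounds shows what this change does on its own. Compound 1 and compound 2 do carry fluoro, but they differ from compound 3 in more than that, so the gap between them and compound 3 at 29000 nM says little about fluoro alone. With so little to go on, no change beyond the scatter is expected in this assay and the estimated step of a 1.1-fold higher number from compound 3 to compound 4 (0.04 log units; within the scatter) is small, with no firm direction. For compound 4 the estimated value is 32000 nM with an expected range from 15000 nM to 68000 nM as the likely span.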

Compound 4, half-maximal inhibitory concentration: 87000 nM
Estimate against measurement, compound 4: 2.7-fold (0.43 log units) below; measured number above the stated range.
By their numbers in this assay, from the lowest: compound 3; then compounds 2, 1 and 4 (each within the scatter of the next).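

In this assay the exchange of hydrogen for fluoro, on the aromatic carbon para to a (hex-5-en-1-yl)oxy group, gives a 3.0-fold higher number from compound 3 to compound 4 (0.48 log units; beyond the scatter) and so makes the inhibitor weaker by a step beyond the usual scatter. For the compounds shown here, this is the first pair in the set that isolates fluoro, and it shows that this position is sensitive to even a small change: one added heavy atom, with no ring, no net charge and no hydrogen-bond donors or acceptors, is enough to shift the number in the weaker direction. Nothing measured here accounts for the shift.

It remains open whether this step is particular to fluoro, as a chloro group, a methyl group or a methoxy group on the same carbon is not among the compounds shown. As far as these compounds go, it is also open whether fluoro would have a similar effect on another carbon of this ring, or in compounds with the two chains joined, like compound 1 and compound 2, whose counterparts with hydrogen in place of fluoro do not appear here.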